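The compounds below may be only part of what the source reports. "The series", "measured", "known", "first", "only" and "open" are said of these compounds alone.

Measured so far in a functional assay on MDA-MB-231 cells (Homo sapiens) for cytotoxicity, read by sulforhodamine B assay, with a stated time of 3 days; a higher number here means a weaker inhibitor, a lower number a stronger inhibitor:
Compound 1 `Nc1ccccc1S(=O)(=O)N1CC(n2cnc3c(Cl)nc(Cl)nc32)OCc2ccccc21` gives 467 nM.
Compound 2 `COC(CN(c1ccccc1CO)S(=O)(=O)c1ccc([N+](=O)[O-])cc1)n1cnc2c(Cl)nc(Cl)nc21` gives 409 nM.

Compound 1 and compound 2 give numbers that lie within the scatter of each other, so the two cannot be told apart in this assay.

Compound 3 `O=S(=O)(c1ccccc1NO)N1CC(n2cnc3c(Cl)nc(Cl)nc32)OCc2ccccc21` differs from compound 1 in one place: hydroxy in place of hydrogen on a nitrogen on an aromatic ring. Among the measured compounds shown here, no measured pair shows what this change does here. Such a small addition is expected to move this assay little, if at all beyond the scatter. Compound 3 is therefore estimated at 500 nM, with a range from 200 nM to 1300 nM. The expected step is a 1.1-fold higher number from compound 1 to compound 3 (0.03 log units; within the scatter).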

Compound 3, half-maximal inhibitory concentration: 487 nM
Compound 3: middle estimate off by 1.0-fold (0.01 log units), on the high side; measured number inside the range.
By their numbers in this assay, from the lowest: compounds 2, 1 and 3 (each within the scatter of the next).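

Among the compounds shown here, the change from amino to hydroxyamino gives a 1.0-fold higher number from compound 1 to compound 3 (0.02 log units; within the scatter) in this assay and is the first step measured at this place on the shared core. At this nitrogen on an aromatic ring, then, this one added oxygen leaves the two compounds indistinguishable in this cytotoxicity read-out. No supporting measurement bears on this result.

The compounds shown leave open whether a larger group on this nitrogen, such as an acetyl group, would separate from compound 1. As far as these compounds go, a carboxylic acid in place of the amino group also remains untested among them.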